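From benzoyl to furan-2-yl: an unmeasured cytotoxicity step

The source may hold more compounds than are shown below. What is called first, only, known or untested is meant among the compounds shown, and "the series" means these compounds.

Of the compounds shown here, two of a shared core have been tested in an ADME assay on PC-3 cells (Homo sapiens) for cytotoxicity, read by WST assay, tested at 100 uM; on this read-out lower numbers stand for less inhibition and higher numbers for more inhibition at the one concentration tested (going by the name of the read-out). Compound 1 `O=C(Nc1ccc(Cl)cn1)C1CCCN(C(=O)c2cc(C(F)(F)F)cc(C(F)(F)F)c2)C1` gives 0% in this assay. Compound 2 `O=C(c1ccccc1)c1cccc(NC(=O)C2CCCN(C(=O)c3cc(C(F)(F)F)cc(C(F)(F)F)c3)C2)c1` gives 0% in this assay, so compound 2 stands level with compound 1 at the digits shown, and the two values lie within the scatter of each other. Compound 3 `O=C(Nc1cccc(-c2ccco2)c1)C1CCCN(C(=O)c2cc(C(F)(F)F)cc(C(F)(F)F)c2)C1` has not yet been measured. It differs from compound 2 in one place: furan-2-yl in place of benzoyl on an aromatic carbon. Going by the values given here, no step between measured compounds that differ in one place is on hand, so the expectation for compound 3 rests on the values of compound 1 and compound 2 alone, both of which show no inhibition. In this assay the expected step is no change at the digits printed from compound 2 to compound 3 (within the scatter), which is expected to stay within the scatter. On that basis compound 3 is estimated at 0% in this assay, with a range from -8% to 12%.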

Compound 3, a percentage reported as inhibition, at one concentration (the size of the read-out at that concentration, not a potency): 0%
For compound 3 middle estimate and measured number coincide at the digits printed; the range from low to high includes it.
By their numbers in this assay, from the lowest: compounds 1, 2 and 3 (each within the scatter of the next).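

In this assay, furan-2-yl on this aromatic carbon of the six-membered ring gives no change at the digits printed from compound 2 to compound 3 (within the scatter) against benzoyl, the first step read at this position, and it shows that a five-membered aromatic ring with 1 hetero atom can replace the benzoyl group here with no shift in the read-out. The wider exchange of 5-chloropyridin-2-yl for 3-(furan-2-yl)phenyl on the amide-type nitrogen gives no change at the digits printed from compound 1 to compound 3 (within the scatter) in the same read-out, so neither change separates the compounds at the one concentration tested. No measured evidence bearing on this result is available.

Whether any group at this position can raise the read-out remains open, since all the groups shown here are aromatic and give the same value. An amine or a carboxylic acid on this aromatic carbon would test that.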